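Chloro for Methoxy on a Weak Nicotinic Antagonist

The source may hold more compounds than are shown below. What is called first, only, known or untested is meant among the compounds shown, and "the series" means these compounds.

Compound 2: `COc1ccc(CC2CC(=O)N(c3ccccc3C(=O)OCC3CCCN(CCCc4ccccc4)C3)C2=O)cc1`, 38900 nM
Compound 1: `COc1ccc(OCCCCCN2CCCC(COC(=O)c3coc4ccccc4c3=O)C2)cc1`, 10000 nM

In an in vitro functional assay on HEK ts201 cells for antagonist activity at Neuronal acetylcholine receptor; alpha4/beta2 (Homo sapiens), read by fluorescence and calcium flux (a lower number here means a stronger inhibitor, a higher number a weaker inhibitor), compound 2 gives 38900 nM, the higher of the two numbers, while compound 1 gives 10000 nM, a gap beyond the usual scatter. Compound 3, `O=C(OCC1CCCN(CCCc2ccccc2)C1)c1ccccc1N1C(=O)CC(Cc2ccc(Cl)cc2)C1=O`, differs from compound 2 by chloro in place of methoxy on an aromatic carbon. Within the data shown here, no two measured compounds differ only at this place, so no measured step shows what this swap does. Only a small step is expected, a 1.3-fold lower number from compound 2 to compound 3 (0.11 log units; within the scatter), within the scatter. Compound 3 is therefore estimated at 30000 nM, between 10000 nM and 100000 nM.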

Compound 3, half-maximal inhibitory concentration: 10700 nM
Compound 3: the middle estimate sits 2.8-fold (0.45 log units) above what was measured; the range from low to high includes it.
By their numbers in this assay, from the lowest: compounds 1 and 3 (each within the scatter of the next); then compound 2.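

Placing a chloro where the methoxy stood, on the aromatic carbon para to a large group, gives in this assay a 3.6-fold lower number from compound 2 to compound 3 (0.56 log units; beyond the scatter). Among these compounds, this is the first measured step at this position, and it shows that the number responds to the group placed there, although the step is modest. Nothing available here explains why the number moves.

Among the compounds shown here, with only this one swap, it remains open how a fluoro, a methyl or an amine at the same place would compare. From the compounds shown here alone, whether the step carries over to a different core also remains open.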